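A few compounds are considered here, and "the series" means these few. Any claim that something is new, unique, unknown or untested is made for them only; others in the source may bear on it.

In an ADME assay on MRC5 cells (Homo sapiens), read by MTT assay, with a stated time of 72 h (a lower number here means a stronger inhibitor, a higher number a weaker inhibitor), three compounds have been measured. Compound 1, `Cc1ncnc2c1c(-c1cc3ccccc3o1)cn2[C@@H]1O[C@H](CO)[C@@H](O)[C@H]1O`, gives 84400 nM in this assay, and compound 2, `Cc1ncnc2c1c(-c1ccoc1)cn2[C@@H]1O[C@H](CO)[C@@H](O)[C@H]1O`, gives 98300 nM. These two differ in one place, (1-benzofuran-2-yl in place of furan-3-yl on an aromatic carbon), and that change makes a step of a 1.2-fold lower number from compound 2 to compound 1 (0.07 log units; within the scatter). Compound 3, `Cc1nc(N)c2c(-c3ccoc3)cn([C@@H]3O[C@H](CO)[C@@H](O)[C@H]3O)c2n1`, reaches only the limit of this assay and reports > 100000 nM. This is the limit of > 100000 nM in this assay, at which 1 of the 3 values shown sits. Compound 3 and compound 2 share the same group on the five-membered ring, but the difference between the two cores is not broken down here.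

Compound 4, `Cc1nc(N)c2c(-c3cc4ccccc4o3)cn([C@@H]3O[C@H](CO)[C@@H](O)[C@H]3O)c2n1`, has not yet been measured in this assay. It differs from compound 3 by 1-benzofuran-2-yl in place of furan-3-yl on an aromatic carbon, which is the same change as that made from compound 2 to compound 1, at a place described in the same words. The step from compound 3 to compound 4 is therefore expected to resemble the earlier one: an expected step of a number no higher from compound 3 to compound 4 (the limit leaves the size open), set beside the measured 1.2-fold lower number from compound 2 to compound 1 (0.07 log units; within the scatter), which lies within the scatter. Because compound 3 gives only the limit > 100000 nM, the expected value for compound 4 may itself fall at the limit rather than as a number. Compound 4 is estimated at 100000 nM in this assay, with an expected range from 60000 nM to 200000 nM.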

Compound 4, half-maximal inhibitory concentration: 91800 nM
Compound 4: the middle estimate sits 1.1-fold (0.04 log units) above what was measured; low and high end bracket the measured number.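

In this assay, carrying the change from furan-3-yl to 1-benzofuran-2-yl over to the core of compound 3 gives an at least 1.0-fold lower number from compound 3 to compound 4 (0.03 log units; that floor lies within the scatter). Set beside the earlier step, this shows that the result on the second core is compatible with the result on the first, where the change stayed within the scatter, but it does not show that the two steps are equal: the same change on two cores in this assay, a 1.2-fold lower number (0.07 log units; within the scatter) from compound 2 to compound 1 and an at least 1.0-fold lower number (0.03 log units; that floor lies within the scatter) from compound 3 to compound 4; the limit leaves it open whether they differ Compound 3 is held at a limit of the assay and not at a number, so the true size of its step could be larger than the floor, and the series cannot show whether the change carries over unaltered: the limit of > 100000 nM in this assay, at which 1 of the 4 values shown sits.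

The compounds shown leave open what the same aromatic carbon would tolerate if it carried something other than these two oxygen-containing aromatic groups, such as an amine, a carboxylic acid or a longer chain, and whether any of these would give a step beyond the scatter. They also leave open whether the change from furan-3-yl to 1-benzofuran-2-yl would behave the same way on any core beyond these two.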